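The source may hold more compounds than are shown below. What is called first, only, known or untested is meant among the compounds shown, and "the series" means these compounds.

Three compounds have been measured so far in a functional assay on KB cells (Homo sapiens) for antiproliferative activity, read by sulforhodamine B assay, with a stated time of 48 h (on this read-out lower numbers stand for stronger inhibition of growth and higher numbers for weaker inhibition of growth), as follows:

Compound 1 (`CNc1nc(Nc2ccc(OC)cc2)nc2ccccc12`) gives 14800 nM
Compound 2 (`N#Cc1ccc(Nc2nc(NC3CCCC3)c3ccccc3n2)cc1`) gives > 31300 nM as a limit of the assay, not a number
Compound 3 (`N#Cc1ccc(Nc2nc(NCCCO)c3ccccc3n2)cc1`) gives 23700 nM

Compound 3 stands within the usual scatter of compound 1 (14800 nM) in this assay on these numbers. The reading for compound 2 is only a limit, so it cannot be ranked exactly.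

The next change keeps the 3-hydroxypropyl group of compound 3 and alters the other end of the molecule: fluoro in place of cyano on an aromatic carbon gives compound 4 (`OCCCNc1nc(Nc2ccc(F)cc2)nc2ccccc12`), a move from 4-cyanophenyl to 4-fluorophenyl.

For the measured compounds named here, the one measured step between compounds differing in a single place is an at least 1.3-fold lower number from compound 2 to compound 3 (0.12 log units; that floor lies within the scatter) and it concerns the cyclopentyl and 3-hydroxypropyl groups, not the cyano group. Going by the values given here, no measured step shows what replacing cyano does, so no direction can be given and no shift beyond the scatter is expected in this assay from this change.

The expected step is a 1.2-fold lower number from compound 3 to compound 4 (0.07 log units; within the scatter) and it stays small. Compound 4 is estimated at 20000 nM in this assay. The expected range for compound 4 runs from 9000 nM to 40000 nM on that estimate.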

Compound 4, concentration for 50% growth inhibition: 17100 nM
For compound 4 the middle estimate is 1.2-fold (0.07 log units) above the measured one, and the stated range covers the measured number.
By their numbers in this assay, from the lowest: compounds 1, 4 and 3 (each within the scatter of the next). At a limit, above all of these: compound 2.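

In this assay, fluoro in place of cyano on an aromatic carbon, para to a large group, gives a 1.4-fold lower number from compound 3 to compound 4 (0.14 log units; within the scatter). For the compounds shown here, this is the first measured change at this end of the molecule, since the earlier step concerned only the cyclopentyl and 3-hydroxypropyl groups. With the 3-hydroxypropyl group held fixed, the cyano group, with the hydrogen-bond acceptor counted on it, can be exchanged for fluoro without a shift beyond the scatter.

On these data alone, it stays open whether an amine or a carboxylic acid on that aromatic carbon would shift the number beyond the scatter, and whether the same exchange would read alike with cyclopentyl in place of 3-hydroxypropyl. That second question has no numerical starting point, as the reading for compound 2 is a limit, not a number: the limit of > 31300 nM in this assay, at which 1 of the 4 values shown sits.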